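Cytotoxicity notes: fluoro removal on the benzyl of compound 1

The source may hold more compounds than are shown below. What is called first, only, known or untested is meant among the compounds shown, and "the series" means these compounds.

Compound 1 `CN(Cc1cccc(F)c1)C(=O)CNC(=O)c1ccc(S(C)(=O)=O)c([N+](=O)[O-])c1` was run in an ADME assay on HepG2 cells (Homo sapiens) for cytotoxicity, read by CellTiter-Glo and ATP content, with a stated time of 72 h; a lower number here means that less compound is needed, a higher number that more compound is needed for the effect. In this assay compound 1 gives > 27000 nM, which is a limit of the assay and not a number. Compound 2 `CS(=O)(=O)c1ccc(C(=O)N2CCC(C(=O)N3CCN(c4ccc(F)cc4)CC3)CC2)cc1[N+](=O)[O-]` shares the core; in this assay compound 2 gives > 27000 nM, again a limit rather than a number. Compound 3 `CCCN(C(=O)CN(C)C(=O)c1ccc(S(C)(=O)=O)c([N+](=O)[O-])c1)c1ccccc1` also shares the core, and in this assay compound 3 gives > 27000 nM, likewise a limit. Every measured value in the series therefore sits at the limit of > 27000 nM in this assay, at which 3 of the 3 values shown sit, so compound 1 stands where the other two stand, and no order among the three can be drawn.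

Compound 4 `CN(Cc1ccccc1)C(=O)CNC(=O)c1ccc(S(C)(=O)=O)c([N+](=O)[O-])c1` differs from compound 1 by hydrogen in place of fluoro on an aromatic carbon. For the measured compounds named here, no step between measured compounds covers this change, so no measured size can be pointed to. Because all values shown rest at the limit of > 27000 nM in this assay, at which 3 of the 3 values shown sit, the series gives no sign that a small change on the benzyl moves the read-out. For compound 4 the step from compound 1 is expected to be a number no higher from compound 1 to compound 4 (the limit leaves the size open), that is, none beyond the scatter. Compound 4 is expected to give 27000 nM, most likely again reported only as a limit. The expected range for compound 4 runs from 13500 nM to 54000 nM.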

Compound 4, half-maximal effective concentration: > 27000 nM
Compound 4 was reported as a limit; the forecaster's own chance of this, stated with the estimate: 85%; the middle value sits exactly at the limit.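

In this assay compound 4 gives > 27000 nM, a limit of the assay and not a number. No step can be read between compound 1 and compound 4, since both values are limits: the limit of > 27000 nM in this assay, at which 4 of the 4 values shown sit.

The compounds shown leave open whether 3-fluorobenzyl to benzyl changes the read-out, and whether any compound on the shared core gives a readable value.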